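This account rests on a few compounds, and the source may have more. Where it says the series, first, only, none or still open, it means among the compounds named here.

The study brings together four compounds built on a shared core, and one assay, an ADME assay on HEK293 cells (Homo sapiens) for cytotoxicity, read by CCK-8 assay and cell counting, with a stated time of 2 days (on this read-out higher numbers stand for weaker inhibition and lower numbers for stronger inhibition), carries the numbers. Compound 1 `Oc1cccc(-c2cc(-c3cccnc3)nc(-c3ccccc3Cl)c2)c1` stands at "not determined" (no result reported) in this assay. Compound 2 `Oc1cccc(-c2cc(-c3cccs3)nc(-c3ccccc3Cl)c2)c1` gives 2600 nM in this assay, and compound 3 `Oc1cccc(-c2cc(-c3ccccc3)nc(-c3ccc(Cl)cc3)c2)c1` gives 11600 nM. On these two numbers compound 3 stands highest; its nearest neighbour is compound 2, whose number lies lower by a gap beyond the usual scatter, while compound 1 adds no number at all.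

Compound 4 `Oc1cccc(-c2cc(-c3ccccc3)nc(-c3ccccc3Cl)c2)c1` keeps every atom of compound 3 but joins them differently: 2-chlorophenyl in place of 4-chlorophenyl on an aromatic carbon. For the measured compounds named here, no step between two measured compounds isolates this change, so its size must be judged from the structures alone. Compound 2 also carries a 2-chlorophenyl group, and its number lies below that of compound 3, but compound 2 differs from compound 4 in another group as well, so it offers only a loose hint. Compound 4 is expected to move from compound 3 by a 1.5-fold lower number from compound 3 to compound 4 (0.16 log units; within the scatter), a step that may sit within the scatter or lean modestly toward a lower number. Compound 4 is therefore estimated at 8000 nM in this assay, with a likely range from 3000 nM to 22000 nM.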

Compound 4, half-maximal inhibitory concentration: 1760 nM
Beside the measured number, compound 4's estimate is 4.5-fold (0.66 log units) above it; the measured number lies below the stated range.
By their numbers in this assay, from the lowest: compounds 4 and 2 (each within the scatter of the next); then compound 3.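

In this assay the chlorine changes place while every atom stays, and this gives a 6.6-fold lower number from compound 3 to compound 4 (0.82 log units; beyond the scatter) on the ring next to the ring nitrogen. For the compounds shown here, this is the first clean reading of the change: compound 2 and compound 3 differ in two places and could only hint at it, whereas this pair shows that 2-chlorophenyl rather than 4-chlorophenyl goes with the lower number on this read-out. With 2-chlorophenyl held fixed, the exchange of the other group gives a 1.5-fold lower number from compound 2 to compound 4 (0.17 log units; within the scatter) and leaves phenyl and thiophen-2-yl unseparated here, while nothing at hand explains why the place of the chlorine counts so much.

The compounds shown leave open whether a 3-chlorophenyl group would sit with the 2-chlorophenyl or the 4-chlorophenyl group, and whether a methyl, a methoxy or an amine in place of the chlorine would keep the number where it stands. They also leave open whether the same step would appear with thiophen-2-yl in place of phenyl, since only the 2-chlorophenyl form carries that ring here.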